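Hydroxy removal on the aromatic ring: cytotoxicity expectation

The compounds below may be only part of what the source reports. "The series", "measured", "known", "first", "only" and "open" are said of these compounds alone.

For the measured compounds named here, compound 1 `O=C(COc1cccc2ccccc12)N/N=C/c1ccc(O)cc1` is the only member of the set with a number rather than a limit. In an ADME assay on HEL cells (Homo sapiens) for cytotoxicity (on this read-out lower numbers stand for higher toxicity in this test and higher numbers for lower toxicity in this test), compound 1 gives 20 ug/mL. Compound 2 `COc1ccc(/C=N/NC(=O)COc2cccc3ccccc23)cc1OC` reaches only a limit in this assay, >= 20 ug/mL; this is the limit of >= 20 ug/mL in this assay, at which 1 of the 3 values shown sits. Compound 3 `C/C(=N\NC(=O)COc1cccc2ccccc12)c1ccc(Cl)cc1` likewise sits at a limit in this assay, >= 4 ug/mL; this is the limit of >= 4 ug/mL in this assay, at which 1 of the 3 values shown sits. Compound 4 `O=C(COc1cccc2ccccc12)N/N=C/c1ccccc1` has not yet been tested; it differs from compound 1 by hydrogen in place of hydroxy on an aromatic carbon. Going by the values given here, no pair of measured compounds differs in a single place, so no measured step guides this change. The expected step in this assay is no change at the digits printed from compound 1 to compound 4 (within the scatter), with no direction beyond the usual scatter. Compound 4 is therefore estimated at 20 ug/mL, in the range 7 ug/mL to 60 ug/mL.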

Compound 4, minimum cytotoxic concentration: 100 ug/mL
For compound 4 the middle estimate is 5.0-fold (0.70 log units) below the measured one; measured number outside the range, above it.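

For the compounds shown here, the 4-hydroxyphenyl to phenyl change gives the first single-place comparison: in this assay, hydrogen in place of hydroxy on an aromatic carbon gives a 5.0-fold higher number from compound 1 to compound 4 (0.70 log units; beyond the scatter). This position therefore matters for the read-out, with the hydroxy-free member reading as less toxic in this test. Nothing shown gives a cause for this step. Steps to compound 2 and compound 3 cannot be read, as both stand at limits and differ from the others in more than one place. Still open, on these data alone, is how an amine or a carboxylic acid on that aromatic carbon would read.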